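This account rests on a few compounds, and the source may have more. Where it says the series, first, only, none or still open, it means among the compounds named here.

Measured compounds, with values in a functional assay on PC-3 cells (Homo sapiens) for inhibition, read by MTT assay, with a stated time of 72 h; a lower number here means a stronger inhibitor, a higher number a weaker inhibitor:
Compound 1 `O=C(CSc1nc(Nc2ccccc2)c2ccccc2n1)Nc1cccc(Br)c1` gives 11400 nM.
Compound 2 `O=C(CSc1nc(Nc2ccccc2)c2ccccc2n1)Nc1cccc([N+](=O)[O-])c1` gives 11800 nM.
Compound 3 `C=CC(=O)Nc1cccc(NC(=O)CSc2nc(Nc3cccc(Br)c3)c3ccccc3n2)c1` gives 15000 nM.

All three values in this assay lie within the scatter of one another, so no order among them is claimed. The change nitro in place of bromo on an aromatic carbon produced the step of a 1.0-fold higher number from compound 1 to compound 2 (0.01 log units; within the scatter). Compound 4 `C=CC(=O)Nc1cccc(NC(=O)CSc2nc(Nc3cccc([N+](=O)[O-])c3)c3ccccc3n2)c1` is not yet measured; it differs from compound 3 by nitro in place of bromo on an aromatic carbon, the same change at the same place. The difference between the core of compound 1 and the core of compound 3 is not broken down here. Within the data shown here, because the single earlier step of a 1.0-fold higher number from compound 1 to compound 2 (0.01 log units; within the scatter) was flat, the step of a 1.0-fold higher number from compound 3 to compound 4 (0.01 log units; within the scatter) is expected to be flat as well. Compound 4 is therefore expected to give about 15500 nM in this assay, estimated between 8000 nM and 30000 nM.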

Compound 4, half-maximal inhibitory concentration: 46300 nM
Estimate against measurement, compound 4: 3.0-fold (0.48 log units) below; the measured number lies above the stated range.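

In this assay, nitro in place of bromo gives a 3.1-fold higher number from compound 3 to compound 4 (0.49 log units; beyond the scatter), and this step does not match the flat earlier one, so the change does not carry over unaltered between these two cores: the same change on two cores in this assay, a 1.0-fold higher number (0.01 log units; within the scatter) from compound 1 to compound 2 and a 3.1-fold higher number (0.49 log units; beyond the scatter) from compound 3 to compound 4, 3.0-fold (0.47 log units) apart, beyond the scatter of two such steps

The outcome of this change therefore depends on the core in these two pairs, with the weaker number appearing only on the core of compound 3. It does not show which feature of the cores sets the difference, and two pairs give no general rule for the series.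

Open, on these data alone, is whether an amine or a carboxylic acid in place of the nitro would give a similar step on the core of compound 3. Also open, as far as these compounds go, is whether that step would persist with a plain acetamide in place of the acrylamide.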